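The source may report more compounds than this note shows. Statements on the series, on what has been measured and on what is new or still open speak of the compounds shown alone.

Compound 1 `Cn1c(-c2ccc([N+](=O)[O-])cc2)nc2cc(C(F)(F)F)ccc21` is assessed in an ADME assay on MDBK cells (Bos taurus) for cytotoxicity, read by MTT assay, with a stated time of 96 h; a lower number here means that less compound is tolerated, a higher number that more compound is tolerated. In this assay compound 1 reaches only a limit, > 100000 nM, so its position is known solely as a boundary at the limit of > 100000 nM in this assay, at which 1 of the 3 values shown sits. Compound 2 `O=[N+]([O-])c1ccc(-c2nc3cc(C(F)(F)F)ccc3[nH]2)cc1` gives 6000 nM in this assay. Compound 3 `O=C(CN1CCCCC1)Nc1ccc(-c2nc3cc(Cl)c(Cl)cc3[nH]2)cc1` gives 45000 nM in this assay.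

Among the measured compounds shown here, the one measured step that differs in a single place is an at least 16-fold lower number from compound 1 to compound 2 (1.22 log units; beyond the scatter). For the measured compounds named here, no measured step shares the change now considered, namely (propanoylamino in place of nitro on an aromatic carbon), which leads to compound 4 `CCC(=O)Nc1ccc(-c2nc3cc(C(F)(F)F)ccc3n2C)cc1`. The step to compound 2 concerns the aromatic nitrogen and not the nitro group, so it does not bear directly on this change. Compound 3 carries an amide on the same position and is tolerated less than the boundary set by compound 1, but compound 3 also differs elsewhere, so nothing can be drawn from it for this step alone. Compound 4 keeps the methyl on the aromatic nitrogen, and the expectation is that it stays at or near the boundary, with the estimated step of a number no higher from compound 1 to compound 4 (the limit leaves the size open) within the scatter. Compound 4 is therefore estimated to give 100000 nM in this assay, expected between 35000 nM and 250000 nM.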

Compound 4, half-maximal cytotoxic concentration: > 100000 nM
Compound 4: a limit, no number; the forecaster's own chance of this, stated with the estimate: 50%; the middle value lies on the limit itself.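

In this assay compound 4 gives > 100000 nM as a limit and not a number. Among the compounds shown here, compound 1 also stands at a limit, so no step from it to compound 4 can be read: the limit of > 100000 nM in this assay, at which 2 of the 4 values shown sit.

Compound 4 carries propanoylamino in place of nitro. The compounds shown leave open the size of the difference in this assay that goes with this change.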